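The source may report more compounds than this note shows. Statements on the series, on what has been measured and on what is new or still open speak of the compounds shown alone.

In a functional assay on L1210 cells (Mus musculus) for inhibition (on this read-out lower numbers stand for stronger inhibition and higher numbers for weaker inhibition), compound 1 `CC(=O)OCCOCn1cnc2c(Cl)ncnc21` gives 475 ug/mL. Compound 2 `CC(=O)OCCOCn1cnc2c(Cl)nc(N)nc21` gives only a limit of the assay, > 1000 ug/mL. The step of an at least 2.1-fold higher number from compound 1 to compound 2 (0.32 log units; beyond the scatter) therefore weakens inhibition. Compound 3 `Nc1nc2c(nc(Cl)n2COCCO)c(=O)[nH]1` also gives only a limit of the assay, > 1000 ug/mL, so it sits at the limit of > 1000 ug/mL in this assay, at which 2 of the 3 values shown sit. Compound 4 `Nc1nc2c(nc(O)n2COCCO)c(=O)[nH]1` differs from compound 3 by hydroxy in place of chloro on an aromatic carbon. For the measured compounds named here, no measured step swaps one group for another in this way; the only measured step concerns a different change, and it gives no guide to the direction here. The starting point of compound 3 is a limit, so the expected step of a number no higher from compound 3 to compound 4 (the limit leaves the size open) is none beyond the scatter. Compound 4 is expected to give 1000 ug/mL, within 500 ug/mL to 2000 ug/mL.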

Compound 4, concentration for 50% inhibition: > 500 ug/mL
Compound 4 ended at the assay's limit; the forecaster's own chance of this, stated with the estimate: 75%; the middle value does not contradict the limit.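

Compound 3 and compound 4 both end at limits of the assay, not at numbers, so the step between them cannot be read. The compounds shown leave open whether hydroxy in place of chloro changes inhibition at all.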